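The compounds below may be only part of what the source reports. "The series", "measured", "known", "first", "only" and "open" are said of these compounds alone.

In an assay on isolated protein (strain Sprague-Dawley) for inhibition of Amine oxidase [flavin-containing] B (Rattus norvegicus), read by spectrophotometry, with a stated time of 5 min (a higher number here means a weaker inhibitor, a lower number a stronger inhibitor), compound 1 `O=c1cc(Cl)c2ccc(OCc3cccc(Cl)c3)cc2o1` gives 20.9 nM. Among the measured compounds shown here, compound 2 `O=c1cc(Oc2ccccc2)c2ccc(OCc3cccc(Cl)c3)cc2o1` gives 4070 nM in this assay, the highest of the two numbers measured so far; its nearest neighbour is compound 1, and the step of a 190-fold higher number from compound 1 to compound 2 (2.29 log units; beyond the scatter) lies beyond the scatter. Compound 3 `CCOC(=O)Nc1cc(=O)oc2cc(OCc3cccc(Cl)c3)ccc12` has not yet been measured. It differs from compound 2 at one place: (ethoxycarbonyl)amino in place of phenoxy on an aromatic carbon. For the measured compounds named here, the only measured step that touches this place is a 190-fold higher number from compound 1 to compound 2 (2.29 log units; beyond the scatter), where the large phenoxy group gave a much weaker inhibitor than the single chloro atom. Compound 3 removes that phenoxy again and puts a group of six heavy atoms with no ring in its place, so a clear drop in the number, toward the value of compound 1, is expected. For compound 3 the step of a 34-fold lower number from compound 2 to compound 3 (1.53 log units; beyond the scatter) is the estimated outcome. Compound 3 is therefore expected to give about 120 nM, most likely between 12 nM and 1500 nM.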

Compound 3, half-maximal inhibitory concentration: 589 nM
Compound 3: the middle estimate sits 4.9-fold (0.69 log units) below what was measured, and the stated range covers the measured number.
By their numbers in this assay, from the lowest: compound 1; then compound 3; then compound 2.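

In this assay, putting (ethoxycarbonyl)amino in place of phenoxy at the position opposite the ring oxygen gives back only part of what phenoxy lost, with a 6.9-fold lower number from compound 2 to compound 3 (0.84 log units; beyond the scatter). The same group still falls well short of the single chloro atom, with a 28-fold higher number from compound 1 to compound 3 (1.45 log units; beyond the scatter). Removing the aromatic ring of phenoxy at this place is therefore not enough on its own to return to the level of compound 1, and a group with no ring can still give a much weaker inhibitor than chloro.

The compounds shown leave open whether a plain amine, a methoxy group or a bromo atom at this position would match chloro, and whether a shorter or longer chain on the carbamate would change the number. No measurement here accounts for the differences among these three groups.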